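Chloro for methyl on the aryl ring at one dose

A few compounds are considered here, and "the series" means these few. Any claim that something is new, unique, unknown or untested is made for them only; others in the source may bear on it.

Three compounds have been examined in an ADME assay on Vero cells (Chlorocebus sabaeus) for cytotoxicity, with a stated time of 72 h, tested at 50 ug/mL; a lower number here means a weaker effect, a higher number a stronger effect of the compound at the concentration tested. Compound 1, `Cc1ccc(N2CCN/C2=N\N)cc1`, gives 9% in this assay. Compound 2, `N=c1c(=O)[nH]nc2n1CCN2c1ccccc1Cl`, gives 2%. Compound 3, `Cc1ccc(N2CCn3c2n[nH]c(=O)c3=N)cc1`, gives 0%, the smallest of the three figures, yet the gaps to compound 2 and to compound 1 both fall within the usual scatter of this assay, so the three compounds cannot be told apart on these numbers.

Compound 4, `N=c1c(=O)[nH]nc2n1CCN2c1ccc(Cl)cc1`, has not yet been measured. It differs from compound 3 in one place: chloro in place of methyl on an aromatic carbon. Among the compounds with values here, no measured pair in this set shows what such a change does, so the expectation rests only on the three numbers above, all of which sit low and close together.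

On that basis compound 4 is expected to give 4% in this assay, within a range of 0% to 15%. The step of a number 4 percentage points higher from compound 3 to compound 4 (within the scatter) is estimated to remain within the scatter, with no direction that the data could support.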

Compound 4, a percentage reported as inhibition, at one concentration (the size of the read-out at that concentration, not a potency): 0%
Compound 4: middle estimate off by 4 percentage points, on the high side; low and high end bracket the measured number.
By their numbers in this assay, from the lowest: compounds 3, 4, 2 and 1 (each within the scatter of the next).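

In this assay, within the data shown here, chloro in place of methyl on an aromatic carbon, para to a large group, gives no change at the digits printed from compound 3 to compound 4 (within the scatter), the first direct one-place comparison in this set. At this position on the six-membered aromatic ring, this change therefore leaves the read-out unmoved at the single concentration tested, although both compounds give so little signal that the comparison cannot show whether the change would matter against a stronger effect. Nothing measured here offers an explanation for this result.

The compounds shown leave open whether a different group at this position, such as an amine or a carboxylic acid, would shift the read-out. They also leave open whether a longer chain in the same place would keep it as low as methyl and chloro do.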